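Aryl variation on the hydrazone of a triazolopyrimidine series

A few compounds are considered here, and "the series" means these few. Any claim that something is new, unique, unknown or untested is made for them only; others in the source may bear on it.

Measured so far in a functional assay on MCF7 cells (Homo sapiens) for antiproliferative activity, read by MTT assay, with a stated time of 72 h; a higher number here means a weaker inhibitor, a lower number a stronger inhibitor:
compound 1 `CCCSc1nc(N/N=C/c2ccc3ccccc3c2)c2nnn(Cc3ccccc3)c2n1`: > 64000 nM.
compound 2 `CCCSc1nc(N/N=C/c2c[nH]c3ccccc23)c2nnn(Cc3ccccc3)c2n1`: 9010 nM.
compound 3 `CCCSc1nc(N/N=C/c2c(O)ccc3ccccc23)c2nnn(Cc3ccccc3)c2n1`: 6400 nM.

The value of compound 1 is a limit of this assay, not a number (the limit of > 64000 nM in this assay, at which 1 of the 3 values shown sits). Compound 3 stands at the low end of the two numbers, but the step of a 1.4-fold lower number from compound 2 to compound 3 (0.15 log units; within the scatter) is within the scatter, so compound 2 and compound 3 are not separated. Both steps from the plain bicyclic aryl are larger: an at least 7.1-fold lower number from compound 1 to compound 2 (0.85 log units; beyond the scatter) and an at least 10-fold lower number from compound 1 to compound 3 (1.00 log units; beyond the scatter).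

Compound 4 `CCCSc1nc(N/N=C/c2ccccc2)c2nnn(Cc3ccccc3)c2n1` is not yet measured. It differs from compound 3 by phenyl in place of 2-hydroxynaphthalen-1-yl on a carbon with a double bond to nitrogen. For the measured compounds named here, no measured step removes a ring in this way; the nearest guide is compound 1, where an aryl without a hydroxy or ring nitrogen reached only the limit, while compound 2 and compound 3 each gave a number. The expectation is therefore a step upward, a 6.3-fold higher number from compound 3 to compound 4 (0.80 log units; beyond the scatter), with a real chance that compound 4 again reaches only a limit. Compound 4 is estimated at 40000 nM, in the range 8000 nM to 120000 nM.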

Compound 4, half-maximal inhibitory concentration: > 64000 nM
Compound 4: no number, only a limit; the forecaster's own chance of this, stated with the estimate: 45%; middle value at least 1.6-fold (0.20 log units) away from the limit.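

In this assay compound 4 gives > 64000 nM which is a limit of the assay and not a number: the limit of > 64000 nM in this assay, at which 2 of the 4 values shown sit.

Phenyl on this carbon with a double bond to nitrogen falls clearly behind both aryl groups that gave numbers (an at least 10-fold higher number from compound 3 to compound 4 (1.00 log units; beyond the scatter); an at least 7.1-fold higher number from compound 2 to compound 4 (0.85 log units; beyond the scatter)). Among the four compounds, only the aryl groups with a hydrogen-bond donor, 2-hydroxynaphthalen-1-yl in compound 3 and 1H-indol-3-yl in compound 2, give numbers, and no compound shown goes against this, while the step between compound 1 and compound 4 cannot be read, as both values are limits.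

Open, going by these compounds, is whether a phenyl carrying a hydroxy or an amine would bring back a number. Also open, on these data alone, is whether the hydroxy itself or the change from naphthalen-2-yl to naphthalen-1-yl separates compound 3 from compound 1.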